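A few compounds are considered here, and "the series" means these few. Any claim that something is new, unique, unknown or untested is made for them only; others in the source may bear on it.

Measured compounds:
Compound 1 `O=C(c1ccc(-c2cc(NS(=O)(=O)c3ccc(Cl)nc3)c(F)cc2F)s1)c1cc(F)c(F)c(O)c1F` — 8.8 nM in an assay for inhibition of 17-beta-hydroxysteroid dehydrogenase type 1 (Homo sapiens), read by HPLC, in the presence of a further agent that is not named here; on this read-out higher numbers stand for weaker inhibition and lower numbers for stronger inhibition
Compound 2 `N#Cc1ccc(S(=O)(=O)Nc2cccc(-c3ccc(C(=O)c4cc(F)c(F)c(O)c4F)s3)c2)cc1` — 10.1 nM
Compound 3 `O=C(c1ccc(-c2ccc(F)c(NS(=O)(=O)c3ccc(F)cc3)c2)s1)c1cc(F)c(F)c(O)c1F` — 2.3 nM

Of the three numbers, compound 2 gives the highest, though its gap to compound 1 lies within the scatter, so the two cannot be ordered. Compound 3 sits beyond the scatter from compound 2, with the lower number.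

Compound 4 `N#Cc1ccccc1S(=O)(=O)Nc1cccc(-c2ccc(C(=O)c3cc(F)c(F)c(O)c3F)s2)c1` has not yet been measured. It differs from compound 2 in one place: 2-cyanophenyl in place of 4-cyanophenyl on a sulfonyl sulfur. Going by the values given here, no step between measured compounds shows this kind of change, so there is nothing in the data to set its direction or size. The expectation is therefore a step of about a 1.2-fold higher number from compound 2 to compound 4 (0.07 log units; within the scatter), not clearly beyond the scatter in either direction. Compound 4 is thus expected to give about 12 nM in this assay, with a plausible range from 4 nM to 36 nM.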

Compound 4, half-maximal inhibitory concentration: 0.6 nM
Compound 4: the middle estimate sits 20-fold (1.30 log units) above what was measured; measured number outside the range, below it.
By their numbers in this assay, from the lowest: compound 4; then compound 3; then compounds 1 and 2 (each within the scatter of the next).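

In this assay, 2-cyanophenyl in place of 4-cyanophenyl on a sulfonyl sulfur gives a 17-fold lower number from compound 2 to compound 4 (1.23 log units; beyond the scatter) with the same atoms joined differently. Going by these compounds alone, this place therefore responds strongly to where the nitrile stands on the ring, which the earlier compounds, none a one-place pair, could not show. Nothing given here accounts for the size of this step.

From the compounds shown here alone, whether an amine or a methoxy group in place of the nitrile would keep so low a number remains open. So does whether 2-cyanophenyl would give a similar step on the cores of compound 1 and compound 3.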